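A few compounds are considered here, and "the series" means these few. Any claim that something is new, unique, unknown or untested is made for them only; others in the source may bear on it.

In a functional assay on the whole organism for inhibition, with Cavia porcellus as the target, with stated times of 1 h and 10 min, at a dose of 0.3 mg/kg by the oral route (on this read-out lower numbers stand for a weaker effect and higher numbers for a stronger effect at the one dose given), compound 2 `Cc1c(CCCC(=O)O)c2cccc(/C=C/c3ccc(OCCCCc4c(F)c(F)cc(F)c4F)cc3)c2n1CC(=O)O` gives 9%. Among the compounds with values here, that is the lower of the two numbers measured so far: compound 1 `O=C(O)CCCc1cn(CC(=O)O)c2c(/C=C/c3ccc(OCCCCc4c(F)ccc(F)c4F)cc3)cccc12` gives 45%, a number that sits beyond the usual scatter above compound 2. Compound 3 `Cc1c(CCCC(=O)O)c2cccc(/C=C/c3ccc(OCCCCc4c(F)cc(F)c(F)c4F)cc3)c2n1CC(=O)O` has not yet been measured in this assay. It differs from compound 2 in one place only, (2,3,4,6-tetrafluorophenyl in place of 2,3,5,6-tetrafluorophenyl on a saturated chain carbon, four bonds along the chain from an oxygen on an aromatic ring). Within the data shown here, no pair of measured compounds that differ in just one place is available, so there is no measured step to show how such a rearrangement of fluorine atoms shifts this read-out. Since the two compounds hold the same atoms joined differently, the step is expected to be modest, quite possibly none beyond the scatter, with a slight lean upward. The step expected from compound 2 to compound 3 is a number 6 percentage points higher from compound 2 to compound 3 (within the scatter). Compound 3 is therefore estimated at 15%, with a range from 0% to 40%.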

Compound 3, a percentage reported as inhibition, in the whole organism at one dose (the size of the read-out at that dose, not a potency): 87%
Beside the measured number, compound 3's estimate is 72 percentage points below it; the whole stated range lies below it.
By their numbers in this assay, from the lowest: compound 2; then compound 1; then compound 3.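

In this assay, putting 2,3,4,6-tetrafluorophenyl in place of 2,3,5,6-tetrafluorophenyl gives a number 78 percentage points higher from compound 2 to compound 3 (beyond the scatter) and so shows that this read-out can respond strongly to a change at this position, on a saturated chain carbon, four bonds along the chain from an oxygen on an aromatic ring. Both groups hold the same counted atoms, so the arrangement of the fluorine atoms on the ring, and not their number, separates this pair of compounds. Nothing available here accounts for the size of this step.

This single pair cannot show which fluorine arrangements favour the read-out in general. As far as these compounds go, how a pentafluorophenyl group, a chlorine atom on the ring or a longer chain would compare at this position remains open.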